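A Mirror-Image Change on a Chlorinated Urea

The source may report more compounds than this note shows. Statements on the series, on what has been measured and on what is new or still open speak of the compounds shown alone.

Measured compounds:
compound 1, `C[C@H](NC(=O)Nc1ccccc1Cl)c1ccccc1`, 104%
compound 2, `C[C@@H](NC(=O)Nc1ccc(Cl)cc1Cl)c1ccccc1`, 99%

Of the compounds shown here, two have been measured so far in an ADME assay on the whole organism with Oryza sativa as the target, tested at 1 uM; a higher number here means a weaker effect of the compound at the concentration tested, a lower number a stronger effect. Compound 1 gives 104%. Compound 2 gives 99%, which is the lower of the two numbers, yet the gap to compound 1 lies within the scatter, so the two readings cannot be told apart.

The next compound, compound 3, has the structure `C[C@H](NC(=O)Nc1ccc(Cl)cc1Cl)c1ccccc1`. Compared with compound 2, the change is the two compounds have the same atoms and bonds and differ only in configuration as drawn: 1 of 1 stereo elements differ; a stereocentre at a saturated chain carbon is drawn R in compound 2 and S in compound 3. Nothing leaves and nothing enters; the two compounds are built from the same atoms and bonds and differ only in configuration as drawn.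

Within the data shown here, no step between measured compounds is available to show how large an effect such a change has in this assay. Both readings so far sit near the level where the compound has little effect at the concentration tested, and they agree within the scatter. For a change that swaps only the drawn configuration at one stereocentre, the expected step from compound 2 to compound 3 is a number 1 percentage points higher from compound 2 to compound 3 (within the scatter), that is, none beyond the scatter. Compound 3 is therefore estimated at 100%, with a range from 85% to 112%.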

Compound 3, a percentage reported as activity, at one concentration (the size of the read-out at that concentration, not a potency): 100%
Beside the measured number, compound 3's estimate shows no gap at the digits printed; low and high end bracket the measured number.
By their numbers in this assay, from the lowest: compounds 2, 3 and 1 (each within the scatter of the next).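

Swapping the drawn configuration at the saturated chain carbon from R to S gives a number 1 percentage points higher from compound 2 to compound 3 (within the scatter), so in this assay this stereocentre, on this dichlorinated urea, shows no effect that can be told from the scatter. The new compound also provides a comparison with the configuration as drawn held the same: chloro in place of hydrogen on an aromatic carbon gives a number 4 percentage points lower from compound 1 to compound 3 (within the scatter), which likewise cannot be told from the scatter. The first of these comparisons is especially clean, since the stereocentre is the only thing that could have separated the two readings: the fact that compounds 2 and 3 differ only in the configuration as drawn

All of these readings stay close together, so the compounds shown do not reveal whether configuration would matter in a compound with a clear effect in this assay. As far as these compounds go, whether an amine, a carboxylic acid or a longer chain on the shared core would move the number beyond the scatter also remains open, as does whether a change of configuration would then make a difference.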